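The source may hold more compounds than are shown below. What is called first, only, known or untested is meant among the compounds shown, and "the series" means these compounds.

Measured so far in a functional assay on the whole organism for inhibition, with Rattus norvegicus as the target, in the maximal electroshock model, at a dose of 25 mg/kg by the intraperitoneal route; a lower number here means less inhibition, a higher number more inhibition at the dose given (going by the name of the read-out):
compound 1 `CN(c1ncnc2c1ncn2Cc1ccccc1)C1CCCC1` — 17%
compound 2 `CN(C=O)c1ncnc2c1ncn2Cc1ccccc1` — 0%

Compound 2 gives the lowest of the two numbers in this assay, the nearest being compound 1, whose value lies beyond the scatter above it. Going by the values given here, the only measured step, a number 17 percentage points lower from compound 1 to compound 2 (beyond the scatter), shows that exchanging the group on the nitrogen on the shared core moves the read-out by a modest amount.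

Compound 3 `CSc1ncnc2c1ncn2Cc1ccccc1` is not yet measured. It differs from compound 2 as follows: methylsulfanyl in place of formyl(methyl)amino on an aromatic carbon. Among the compounds with values here, no measured pair changes this position in the same way, so the step from compound 1 to compound 2 bears on it only in that it concerns the same point of the core. The expectation is therefore a step no larger than that one, in an uncertain direction, at most modest. Compound 3 is estimated at 10% (range 0% to 30%), a step of a number 10 percentage points higher from compound 2 to compound 3 (within the scatter) that is expected to stay near the scatter.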

Compound 3, a percentage reported as inhibition, in the whole organism at one dose (the size of the read-out at that dose, not a potency): 30%
Beside the measured number, compound 3's estimate is 20 percentage points below it; the measured number falls inside the stated range.
By their numbers in this assay, from the lowest: compound 2; then compound 1; then compound 3.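

In this assay, this place on the aromatic carbon now shows that the read-out can rise as well as fall: the change to methylsulfanyl from formyl(methyl)amino gives a number 30 percentage points higher from compound 2 to compound 3 (beyond the scatter) in the series. Methylsulfanyl in place of cyclopentyl(methyl)amino gives a number 13 percentage points higher from compound 1 to compound 3 (beyond the scatter) as well, so compound 3 stands highest of the three, with both of its steps beyond the scatter. Nothing available explains either step.

The compounds shown leave open whether ethylsulfanyl or benzylsulfanyl, with a longer chain on the sulfur, or methoxy, with oxygen in place of sulfur, would keep the read-out of compound 3. They also leave open how the read-out of compound 3 changes with dose, since each number here comes from a single dose.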